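Aryl amine exchange on the cyclobutanecarboxamide series

This account rests on a few compounds, and the source may have more. Where it says the series, first, only, none or still open, it means among the compounds named here.

Measured so far in an assay on isolated protein for inhibition of serine/threonine-protein kinase TBK1 (Homo sapiens); a lower number here means a stronger inhibitor, a higher number a weaker inhibitor:
- compound 1 `CC(C)c1cnc(Nc2cccc(F)c2)nc1NCCCNC(=O)C1CCC1`: a limit, > 1000 nM
- compound 2 `O=C(NCCCNc1nc(Nc2cccc(F)c2)ncc1Br)C1CCC1`: 2 nM
- compound 3 `O=C(NCCCNc1nc(Nc2cnn(C3CC3)c2)ncc1C1CC1)C1CCC1`: 10 nM

Compound 3 holds the highest of the two numbers obtained; compound 2 lies closer, and the third value for compound 1 is only a limit of this assay (the limit of > 1000 nM in this assay, at which 1 of the 3 values shown sits). Going by the values given here, the one measured step, an at least 500-fold lower number from compound 1 to compound 2 (2.69 log units; beyond the scatter), concerns the group on the aromatic carbon and does not touch the amine.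

Compound 4 `O=C(NCCCNc1nc(Nc2cccc(F)c2)ncc1C1CC1)C1CCC1` differs from compound 3 by 3-fluorophenyl in place of 1-cyclopropyl-1H-pyrazol-4-yl on a nitrogen on an aromatic ring. Among the compounds with values here, no measured step covers this exchange, so the expectation rests on compound 2 carrying the same 3-fluorophenyl at 2 nM. A modest step is expected, a 2.0-fold lower number from compound 3 to compound 4 (0.30 log units; within the scatter). Compound 4 is estimated at 5 nM, between 1.5 nM and 20 nM.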

Compound 4, half-maximal inhibitory concentration: 8 nM
The estimate for compound 4 lay 1.6-fold (0.20 log units) below the measured number; measured number inside the range.
By their numbers in this assay, from the lowest: compound 2; then compounds 4 and 3 (each within the scatter of the next). At a limit, above all of these: compound 1.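

On a nitrogen on an aromatic ring, 3-fluorophenyl in place of 1-cyclopropyl-1H-pyrazol-4-yl gives in this assay a 1.3-fold lower number from compound 3 to compound 4 (0.10 log units; within the scatter), so the two amines cannot be told apart with cyclopropyl on the aromatic carbon. With 3-fluorophenyl held, the aromatic carbon carries the larger differences: cyclopropyl in place of bromo gives a 4.0-fold higher number from compound 2 to compound 4 (0.60 log units; beyond the scatter), and cyclopropyl in place of isopropyl gives an at least 120-fold lower number from compound 1 to compound 4 (2.09 log units; beyond the scatter). Compound 1 stands only at a limit of the assay: the limit of > 1000 nM in this assay, at which 1 of the 4 values shown sits.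

From the compounds shown here alone, whether 1-cyclopropyl-1H-pyrazol-4-yl matches 3-fluorophenyl with bromo on the aromatic carbon remains open. So does the effect of chloro or methyl there.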